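Methoxy to Methylsulfanyl on a Prostacyclin Synthase Inhibitor Core

The source may hold more compounds than are shown below. What is called first, only, known or untested is meant among the compounds shown, and "the series" means these compounds.

Measured so far:
compound 1, `CC(C)(Oc1ccccc1)C1OCC(C/C=C\CCC(=O)O)C(c2cccnc2)O1`: 75000 nM
compound 2, `COc1ccccc1OC(C)(C)C1OCC(C/C=C\CCC(=O)O)C(c2cccnc2)O1`: 51000 nM

Both compounds share one core and were tested in an assay for inhibition of prostacyclin synthase (Homo sapiens), using microsomes; on this read-out lower numbers stand for stronger inhibition and higher numbers for weaker inhibition. Compound 2 gives the lower of the two numbers, but the distance to compound 1 is small: a 1.5-fold lower number from compound 1 to compound 2 (0.17 log units; within the scatter), so the two values cannot be told apart.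

Compound 3, `CSc1ccccc1OC(C)(C)C1OCC(C/C=C\CCC(=O)O)C(c2cccnc2)O1`, has not been measured. It differs from compound 2 in one place: methylsulfanyl in place of methoxy on an aromatic carbon. Within the data shown here, no measured step involves a methylsulfanyl group, so the only guidance is the step from compound 1 to compound 2, which stayed within the scatter when a small group was introduced at this position. Nothing in the data therefore points to a shift in either direction in this assay. The expectation for compound 3 is a value close to that of compound 2, a 1.1-fold lower number from compound 2 to compound 3 (0.05 log units; within the scatter), with a wide uncertainty. The estimate for compound 3 is 45000 nM, in a range from 15000 nM to 150000 nM.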

Compound 3, half-maximal inhibitory concentration: > 100000 nM
Compound 3 gave a limit, no number; the forecaster's own chance of this, stated with the estimate: 15%; middle value at least 2.2-fold (0.34 log units) from the limit.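

In this assay compound 3 gives > 100000 nM, which is a limit of the assay and not a number. Measured against the methoxy group the change reads an at least 1.9-fold higher number from compound 2 to compound 3 (0.29 log units; that floor lies within the scatter), and measured against plain hydrogen it reads an at least 1.3-fold higher number from compound 1 to compound 3 (0.12 log units; that floor lies within the scatter). Methylsulfanyl at this place, ortho to a large group, thus shows no sign of stronger inhibition, but both floors lie within the scatter, so a real loss is not established either, and one of the values shown already sits at this ceiling of the read-out: the limit of > 100000 nM in this assay, at which 1 of the 3 values shown sits.

The compounds shown leave open what actual number compound 3 would give. They also leave open how an amine, a hydroxyl group or a longer chain such as ethoxy would read at this place on the shared core.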